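Dropping an Acetyl Group: Expected Shift in Lipophilicity

The compounds below may be only part of what the source reports. "The series", "measured", "known", "first", "only" and "open" are said of these compounds alone.

Compound 1, `CNc1nc(NCCCN(C)C)c2sc(-c3ccc(C(C)=O)cc3)cc2n1`: 2.9
Compound 2, `CNc1nc(NCCCN(C)C)c2sc(-c3ccc(C(F)(F)F)cc3Cl)cc2n1`: 4.5

Among the compounds with values here, in a physicochemical assay for lipophilicity, read by HPLC, at pH 7.4 (on this read-out higher numbers stand for higher lipophilicity and lower numbers for lower lipophilicity), compound 1 gives 2.9, the lower of the two numbers measured so far. Compound 2 gives 4.5, a value beyond the scatter above compound 1. Compound 3, `CNc1nc(NCCCN(C)C)c2sc(-c3ccccc3)cc2n1`, has not yet been measured. It differs from compound 1 in one place: hydrogen in place of acetyl on an aromatic carbon. Within the data shown here, no measured pair shows this same change, so the expectation rests on the change itself. For compound 3 a small rise in this assay is expected, a number 0.50 log units higher from compound 1 to compound 3 (beyond the scatter). The estimate for compound 3 is 3.4, with a range from 2.9 to 3.9.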

Compound 3, distribution coefficient: 2.2
Estimate against measurement, compound 3: 1.20 log units above; the measured number lies below the stated range.
By their numbers in this assay, from the lowest: compound 3; then compound 1; then compound 2.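

Swapping acetyl for hydrogen at this aromatic carbon gives a number 0.70 log units lower from compound 1 to compound 3 (beyond the scatter) in this assay, so at this place the compound carrying the acetyl group is the higher of the pair. The step runs downward for this single change on the shared core. No available measurement accounts for the direction of this step.

The compounds shown leave open how other groups at this carbon, such as an amine, a carboxylic acid or a longer carbon chain, would compare with acetyl and hydrogen. They also leave open whether the same change gives a similar step elsewhere on the ring.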